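Trimming the Ester Ring in an Adenosine A2b Series

This account rests on a few compounds, and the source may have more. Where it says the series, first, only, none or still open, it means among the compounds named here.

In an assay on membranes from HEK293 cells for displacement of a labelled ligand from adenosine receptor A2b (Homo sapiens), read by scintillation counting, with a stated time of 30 min (a higher number here means a weaker inhibitor, a lower number a stronger inhibitor), compound 1 `CC1=C(C(=O)SC(C)C)C(c2ccoc2)NC(=O)N1` gives 637 nM, while compound 2 `CC1=C(C(=O)OC2CCCC2)C(c2ccoc2)NC(=O)N1` gives 1010 nM. Going by the values given here, compound 2 is one of only two measured numbers, and the step of a 1.6-fold higher number from compound 1 to compound 2 (0.20 log units; within the scatter) lies within the scatter, so the two compounds cannot be told apart. Compound 3 `CC1=C(C(=O)OCC2CC2)C(c2ccoc2)NC(=O)N1` differs from compound 2 by cyclopropylmethyl in place of cyclopentyl on an oxygen next to a carbonyl group. Among the compounds with values here, the single measured step also altered the group at that place and stayed within the scatter, which is the closest guide available. The step of a 1.0-fold lower number from compound 2 to compound 3 (0.00 log units; within the scatter) is therefore expected to stay within the scatter. Compound 3 is estimated at 1000 nM, with a range from 400 nM to 2500 nM.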

Compound 3, inhibition constant: 426 nM
Compound 3: the middle estimate sits 2.3-fold (0.37 log units) above what was measured, and the stated range covers the measured number.
By their numbers in this assay, from the lowest: compounds 3, 1 and 2 (each within the scatter of the next, the first and the last beyond it).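

Going by these compounds alone, on an oxygen next to a carbonyl group, cyclopropylmethyl in place of cyclopentyl gives a 2.4-fold lower number from compound 2 to compound 3 (0.37 log units; beyond the scatter), the first step here beyond the scatter, so the group at this place can modestly alter the number. By contrast, a 1.5-fold lower number from compound 1 to compound 3 (0.17 log units; within the scatter) stays within the scatter, so cyclopropylmethoxy and isopropylsulfanyl cannot be told apart. No evidence is available to explain the difference between cyclopentyl and cyclopropylmethyl. On these data alone, it remains open whether the ring size or the chain linking the ring matters, and how an open butyl chain or an amine would behave at this place.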